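The source may report more compounds than this note shows. Statements on the series, on what has been measured and on what is new or still open speak of the compounds shown alone.

Measured compounds:
compound 1, `CC(C)c1ccc(-c2nc(SCc3cn(CC(=O)NC(=O)Nc4ccccn4)nn3)nc(Nc3ccccc3Cl)c2C#N)cc1`, 43700 nM
compound 2, `Cc1ccccc1Nc1nc(SCc2cn(CC(=O)NC(=O)Nc3ccccn3)nn2)nc(-c2ccc(C(C)C)cc2)c1C#N`, > 64000 nM

In a functional assay on MCF7 cells (Homo sapiens) for inhibition, read by MTT assay, with a stated time of 72 h (on this read-out lower numbers stand for stronger inhibition and higher numbers for weaker inhibition), compound 1 gives 43700 nM. For compound 2 the value > 64000 nM is a limit of the assay, not a number. Among the compounds with values here, the one measured step, an at least 1.4-fold higher number from compound 1 to compound 2 (0.16 log units; that floor lies within the scatter), changes the same position and stays inside the scatter, ending at the limit of > 64000 nM in this assay, at which 1 of the 2 values shown sits. Compound 3, `COc1ccccc1Nc1nc(SCc2cn(CC(=O)NC(=O)Nc3ccccn3)nn2)nc(-c2ccc(C(C)C)cc2)c1C#N`, differs from compound 2 by methoxy in place of methyl on an aromatic carbon. No step beyond the scatter is expected: a number no higher from compound 2 to compound 3 (the limit leaves the size open). Compound 3 is therefore estimated at 64000 nM, between 30000 nM and 150000 nM, with a fair chance of another limit.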

Compound 3, half-maximal inhibitory concentration: 19300 nM
Beside the measured number, compound 3's estimate is 3.3-fold (0.52 log units) above it, and the stated range ends above it.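

On an aromatic carbon ortho to a large group, the choice of substituent now makes a clear difference in this assay, which the earlier step, with its floor inside the scatter, could not show. Methoxy in place of methyl gives an at least 3.3-fold lower number from compound 2 to compound 3 (0.52 log units; beyond the scatter), and methoxy in place of chloro gives a 2.3-fold lower number from compound 1 to compound 3 (0.35 log units; beyond the scatter). Compound 2 stands at a limit of the assay, so the first of these steps has no known full size: the limit of > 64000 nM in this assay, at which 1 of the 3 values shown sits.

Still open, going by these compounds, is whether an ethoxy group, a hydroxyl group or an amine at the same place would lower the number further.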